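Estimating compound 4 from three measured relatives

The source may hold more compounds than are shown below. What is called first, only, known or untested is meant among the compounds shown, and "the series" means these compounds.

In a functional assay on SW480 cells (Homo sapiens) for antiproliferative activity, read by sulforhodamine B assay, with a stated time of 48 h (on this read-out higher numbers stand for weaker inhibition and lower numbers for stronger inhibition), compound 1 (`COc1ccc(OC)c(/C=C/C(=O)C(=Cc2ccc(O)c(OC)c2)C(=O)/C=C/c2cc(OC)ccc2OC)c1`) gives 410 nM and compound 2 (`COc1ccc(OC)c(/C=C/C(=O)C(=Cc2cc(OC)c(O)c(OC)c2)C(=O)/C=C/c2cc(OC)ccc2OC)c1`) gives 500 nM. Compound 3 (`COc1ccc(/C=C/C(=O)C(=Cc2ccc(O)c(F)c2)C(=O)/C=C/c2ccc(OC)cc2OC)c(OC)c1`) gives 3350 nM, the highest of the three numbers and so the weakest inhibition measured here. Compound 4 (`COc1ccc(/C=C/C(=O)C(=Cc2ccc(OC)c(O)c2)C(=O)/C=C/c2ccc(OC)cc2OC)c(OC)c1`) is still unmeasured and differs from compound 3 in one place: 3-hydroxy-4-methoxyphenyl in place of 3-fluoro-4-hydroxyphenyl on a double-bonded chain carbon bound to a double-bonded chain carbon.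

Among the measured compounds shown here, only one measured step touches the aromatic ring that changes here. It is a 1.2-fold higher number from compound 1 to compound 2 (0.09 log units; within the scatter), for methoxy in place of hydrogen on an aromatic carbon, and it lies within the scatter. For the measured compounds named here, no measured step isolates the loss of fluorine. Compound 4 shares a ring bearing hydroxy and methoxy groups with compound 1 at 410 nM, but the two also differ elsewhere, so this is only a loose guide. A partial move toward stronger inhibition in this assay therefore seems likely. The expected step is a 2.8-fold lower number from compound 3 to compound 4 (0.45 log units; beyond the scatter). For compound 4 the estimated value is 1200 nM, with an expected range of 350 nM to 4000 nM.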

Compound 4, half-maximal inhibitory concentration: 1370 nM
The estimate for compound 4 lay 1.1-fold (0.06 log units) below the measured number; the measured number falls inside the stated range.
By their numbers in this assay, from the lowest: compounds 1 and 2 (each within the scatter of the next); then compound 4; then compound 3.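

Exchanging 3-fluoro-4-hydroxyphenyl for 3-hydroxy-4-methoxyphenyl on a double-bonded chain carbon bound to a double-bonded chain carbon gives a 2.4-fold lower number from compound 3 to compound 4 (0.39 log units; beyond the scatter) in this assay, toward stronger inhibition, though the change is modest. Among the compounds shown here, the only earlier step on this ring, a 1.2-fold higher number from compound 1 to compound 2 (0.09 log units; within the scatter), stayed within the scatter, so this is the first sign here that a change to the ring at this position can move the number beyond it. No supporting data are available to explain the shift.

The exchange removes fluorine and changes the hydroxy and methoxy groups in a single step, so the compounds shown leave open which of these changes accounts for the difference. They also leave open how the number would respond to an amine in place of the hydroxy group of 3-hydroxy-4-methoxyphenyl.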